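Cyclohexylmethoxy in place of phenoxyethoxy: compound 4

The source may report more compounds than this note shows. Statements on the series, on what has been measured and on what is new or still open speak of the compounds shown alone.

Measured so far:
compound 1 `O=C1OC(Cc2nc(-c3ccc(-c4ccccc4)cc3)no2)c2ccccc21`: > 10000 nM (a limit of the assay)
compound 2 `CCCCOc1ccc(C(O)C2OC(=O)c3c(OC)cc(OC)cc32)cc1`: 1800 nM
compound 3 `COc1cc(OC)c2c(c1)C(C(O)c1ccc(OCCOc3ccccc3)cc1)OC2=O`: > 10000 nM (a limit of the assay)

In a functional assay on RAW264.7 cells (Mus musculus) for inhibition, read by Griess assay, with stated times of 1 h and 24 h (a lower number here means a stronger inhibitor, a higher number a weaker inhibitor), compound 2 gives 1800 nM. For compound 3 this assay reports only a limit, > 10000 nM. Compound 3 thus sits at the limit of > 10000 nM in this assay, at which 2 of the 3 values shown sit, so no number stands for it. Among the measured compounds shown here, the one measured step, an at least 5.5-fold higher number from compound 2 to compound 3 (0.74 log units; beyond the scatter), is the only one that touches this part of the molecule.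

Compound 4 `COc1cc(OC)c2c(c1)C(C(O)c1ccc(OCC3CCCCC3)cc1)OC2=O` is not yet measured. It differs from compound 3 by cyclohexyl in place of phenoxymethyl on a saturated chain carbon bound to an oxygen on an aromatic ring. The change removes the phenoxy that entered in the step from compound 2 to compound 3, so a move back toward the number of compound 2 is expected, though a limit remains possible. Compound 4 is therefore estimated at 5000 nM, between 1500 nM and 15000 nM, an expected at least 2.0-fold lower number from compound 3 to compound 4 (0.30 log units; that floor lies within the scatter).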

Compound 4, half-maximal inhibitory concentration: > 10000 nM
Compound 4: a limit, no number; the forecaster's own chance of this, stated with the estimate: 40%; middle value at least 2.0-fold (0.30 log units) away from the limit.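

Replacing 2-phenoxyethoxy with cyclohexylmethoxy does not bring back a measurable number: compound 4 remains a limit of the assay in this assay, so an aromatic ring in the substituent is not required for this outcome. Cyclohexyl in place of propyl gives an at least 5.5-fold higher number from compound 2 to compound 4 (0.74 log units; beyond the scatter), leaving compound 2 as the only compound shown at this position with a number. The step between compound 3 and compound 4 cannot be read, and the series now gathers at one end: the limit of > 10000 nM in this assay, at which 3 of the 4 values shown sit.

Still open, from the compounds shown here alone, is whether a shorter chain such as ethoxy, or an amine at the end of the chain, keeps or improves on the value of compound 2, 1800 nM.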